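The source may report more compounds than this note shows. Statements on the series, on what has been measured and on what is new or still open speak of the compounds shown alone.

Measured so far:
compound 1 `NC(=O)c1c(NC(=O)c2ccccc2Cl)sc2c1CCN(C(=S)Nc1ccccc1C(F)(F)F)C2` — 1870 nM
compound 2 `Cc1ccccc1NC(=S)N1CCc2c(sc(NC(=O)c3ccccc3Cl)c2C(N)=O)C1` — 11700 nM
compound 3 `Cc1ccccc1C(=O)Nc1sc2c(c1C(N)=O)CCN(C(=S)Nc1ccccc1C(F)(F)F)C2` — 17400 nM

All three were run in a functional assay on MKN-74 cells (Homo sapiens) for antiproliferative activity, with a stated time of 24 h; on this read-out lower numbers stand for stronger inhibition and higher numbers for weaker inhibition. Compound 1 gives the lowest number of the three. Compound 2 differs from compound 1 by methyl in place of trifluoromethyl on an aromatic carbon; the step is a 6.3-fold higher number from compound 1 to compound 2 (0.80 log units; beyond the scatter). Compound 3 differs from compound 1 by methyl in place of chloro on an aromatic carbon; the step is a 9.3-fold higher number from compound 1 to compound 3 (0.97 log units; beyond the scatter). The numbers for compound 2 and compound 3 lie within the usual scatter of each other, so no order between them is claimed.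

Compound 4 `Cc1ccccc1NC(=S)N1CCc2c(sc(NC(=O)c3ccccc3C)c2C(N)=O)C1` has not been measured. It differs from compound 3 by methyl in place of trifluoromethyl on an aromatic carbon, the same change as from compound 1 to compound 2, made here on the core of compound 3, which differs from the core of compound 1 as described above. Its place is described in the same words in both pairs, so it is taken as the same change. Because the earlier step was a 6.3-fold higher number from compound 1 to compound 2 (0.80 log units; beyond the scatter), a step of similar direction is expected from compound 3 to compound 4 in this assay, about a 4.0-fold higher number from compound 3 to compound 4 (0.60 log units; beyond the scatter), though with one example only the size is uncertain and the assay may report a limit. Compound 4 is estimated at 70000 nM, with a range from 25000 nM to 200000 nM.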

Compound 4, half-maximal inhibitory concentration: > 50000 nM
Compound 4 ended at the assay's limit (the forecaster's own chance of this, stated with the estimate: 35%); the middle value is on the limit's open side.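

In this assay compound 4 gives > 50000 nM, which is a limit of the assay and not a number. Methyl in place of trifluoromethyl goes the same way on the second core, with an at least 2.8-fold higher number from compound 3 to compound 4 (0.45 log units; beyond the scatter), so the direction carries over, while whether the size carries over stays unsettled: the same change on two cores in this assay, a 6.3-fold higher number (0.80 log units; beyond the scatter) from compound 1 to compound 2 and an at least 2.8-fold higher number (0.45 log units; beyond the scatter) from compound 3 to compound 4; the limit leaves it open whether they differ. Methyl in place of chloro behaves alike, with an at least 4.2-fold higher number from compound 2 to compound 4 (0.63 log units; beyond the scatter), and again only the direction is shown to carry over, not the size: the same change on two cores in this assay, a 9.3-fold higher number (0.97 log units; beyond the scatter) from compound 1 to compound 3 and an at least 4.2-fold higher number (0.63 log units; beyond the scatter) from compound 2 to compound 4; the limit leaves it open whether they differ.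

The compounds shown leave open whether either direction holds for other groups, such as a methoxy or a nitrile in place of trifluoromethyl on the 2-(trifluoromethyl)phenyl group, or an amine or a carboxylic acid in place of chloro. Going by these compounds alone, they also cover only two changes on this one scaffold, so nothing can be said about whether the direction holds once the shared core itself is altered.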